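Chlorine on the phenyl of a tetrabromo-imidazole tetrazole

The compounds below may be only part of what the source reports. "The series", "measured", "known", "first", "only" and "open" are said of these compounds alone.

Measured compounds:
compound 1, `Brc1c(Br)c(Br)c2c(ncn2CCCn2nnc(-c3ccccc3)n2)c1Br`, 106%
compound 2, `Brc1c(Br)c(Br)c2c(ncn2CCCn2nnnc2-c2ccccc2)c1Br`, 67%

Of the compounds shown here, two have been measured in a functional assay on CCRF-CEM cells (Homo sapiens) for cytotoxicity, read by MTT assay, with a stated time of 24 h, tested at 10 uM; a higher number here means a weaker effect of the compound at the concentration tested, a lower number a stronger effect. Compound 1 gives 106% in this assay. Compound 2 gives 67% in this assay, the lowest of the two numbers and therefore the stronger effect; its nearest neighbour is compound 1, which stands a gap above it that lies beyond the scatter. Among the measured compounds shown here, the two differ only in how the phenyl-bearing tetrazole is attached to the three-carbon chain, and no single-site step between them is counted here, so only their two values speak.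

Compound 3, `Clc1ccccc1-c1nnnn1CCCn1cnc2c(Br)c(Br)c(Br)c(Br)c21`, is the next compound to be measured in this assay. Its change from compound 2 is chloro in place of hydrogen on an aromatic carbon; read one bond further out, phenyl becomes 2-chlorophenyl. The shared core and the chain are untouched. For the measured compounds named here, nothing among the measured compounds shows what a chloro on that ring does, so the step is expected to be small, in either direction, or none beyond the scatter: a number 4 percentage points lower from compound 2 to compound 3 (within the scatter). Compound 3 is thus estimated at 63%, within 42% to 84%.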

Compound 3, a percentage reported as inhibition, at one concentration (the size of the read-out at that concentration, not a potency): 65%
For compound 3 the middle estimate is 2 percentage points below the measured one; the measured number falls inside the stated range.
By their numbers in this assay, from the lowest: compounds 3 and 2 (each within the scatter of the next); then compound 1.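

In this assay, putting chloro in place of hydrogen on an aromatic carbon, so that phenyl becomes 2-chlorophenyl, gives a number 2 percentage points lower from compound 2 to compound 3 (within the scatter). Among the compounds shown here, this is the first direct reading of a change on this ring: at this place, ortho to a large group on the six-membered aromatic ring of carbon only, a single chlorine leaves the read-out indistinguishable from that of the unsubstituted phenyl, and the shared core and the chain stay as they were. Nothing available bears on why the step is this small, and one step at one concentration supports no broader rule for this ring.

The compounds shown leave open whether a different group at this place, such as a methoxy, an amine or a carboxylic acid, would also leave the read-out within the scatter, and whether chloro elsewhere on the ring would behave in the same way. They also leave open whether the same chloro change would give a similar step on the other tetrazole attachment seen in compound 1, or on a compound with a longer chain.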